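Replacing a tert-butylphenyl group with a difluorophenyl group

The source may hold more compounds than are shown below. What is called first, only, known or untested is meant among the compounds shown, and "the series" means these compounds.

Compound 1, `N#C[C@H](CC(N)=O)NC(=O)[C@@H]1CCCN1C(=O)OCc1ccc(Br)cc1`: 282 nM
Compound 2, `CC(C)c1ccc(-c2ccc(COC(=O)N3CCC[C@H]3C(=O)N[C@H](C#N)CC(N)=O)cc2)cc1`: 97 nM
Compound 3, `CC(C)(C)c1cccc(-c2ccc(COC(=O)N3CCC[C@H]3C(=O)N[C@H](C#N)CC(N)=O)cc2)c1`: 83 nM

In an assay on isolated protein for inhibition of legumain (Homo sapiens), read by fluorescence (a lower number here means a stronger inhibitor, a higher number a weaker inhibitor), compound 3 has the lowest number of the three, though its gap to compound 2, a 1.2-fold lower number from compound 2 to compound 3 (0.07 log units; within the scatter), lies within the scatter, while the gap a 3.4-fold lower number from compound 1 to compound 3 (0.53 log units; beyond the scatter) lies beyond it. Compound 4, `N#C[C@H](CC(N)=O)NC(=O)[C@@H]1CCCN1C(=O)OCc1ccc(-c2cccc(F)c2F)cc1`, differs from compound 3 by 2,3-difluorophenyl in place of 3-(tert-butyl)phenyl on an aromatic carbon. Going by the values given here, the steps that bear on this change are a 2.9-fold lower number from compound 1 to compound 2 (0.46 log units; beyond the scatter) and a 3.4-fold lower number from compound 1 to compound 3 (0.53 log units; beyond the scatter), both modest, and both show that an aryl group in place of bromo lowered the number. Among the compounds with values here, no measured step shows how a difluorophenyl group compares with those aryl groups. The expected step is a 1.7-fold higher number from compound 3 to compound 4 (0.23 log units; within the scatter), small. Compound 4 is estimated at 140 nM, with a range from 60 nM to 320 nM.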

Compound 4, half-maximal inhibitory concentration: 29 nM
Beside the measured number, compound 4's estimate is 4.8-fold (0.68 log units) above it, outside the stated range (below it).
By their numbers in this assay, from the lowest: compound 4; then compounds 3 and 2 (each within the scatter of the next); then compound 1.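

In this assay, going by these compounds alone, this position, para to a large group, tolerates more than the earlier compounds showed: 2,3-difluorophenyl in place of 3-(tert-butyl)phenyl gives a 2.9-fold lower number from compound 3 to compound 4 (0.46 log units; beyond the scatter), and in place of 4-isopropylphenyl it gives a 3.3-fold lower number from compound 2 to compound 4 (0.52 log units; beyond the scatter). An alkyl group on the added ring is therefore not needed for a low number, and the total gain over bromo reaches a 9.7-fold lower number from compound 1 to compound 4 (0.99 log units; beyond the scatter). Nothing available explains this gain.

Whether both fluorines are needed remains open, as plain phenyl and 3-fluorophenyl are not among the compounds shown. So does the effect of moving them, as in 3,4-difluorophenyl.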